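This account rests on a few compounds, and the source may have more. Where it says the series, first, only, none or still open, it means among the compounds named here.

Three compounds with a shared core differ only in the halogen-bearing phenyl group on a double-bonded chain carbon bound to a double-bonded ring carbon. In an ADME assay on NHDF cells (Homo sapiens) for cytotoxicity, read by MTT assay, with a stated time of 72 h (a lower number here means a stronger inhibitor, a higher number a weaker inhibitor), compound 1 (`COc1ccc(/C=C2\CCC/C(=C\c3ccccc3Br)C2=O)cc1OC`) gives 21800 nM, and compound 2 (`COc1ccc(/C=C2\CCC/C(=C\c3ccc(Br)cc3)C2=O)cc1OC`) gives 13100 nM. Compound 3 (`COc1ccc(/C=C2\CCC/C(=C\c3ccc(Cl)cc3Cl)C2=O)cc1OC`) gives > 50000 nM, which is a limit of the assay and not a number. The other two compounds therefore have measured numbers, while compound 3 has only this limit. Its two steps, an at least 2.2-fold higher number from compound 1 to compound 3 (0.36 log units; beyond the scatter) and an at least 3.8-fold higher number from compound 2 to compound 3 (0.58 log units; beyond the scatter), are also bounds rather than exact sizes.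

Compound 4 (`COc1ccc(/C=C2\CCC/C(=C\c3cc(Cl)cc(Cl)c3)C2=O)cc1OC`) has the same atoms as compound 3, joined differently: 3,5-dichlorophenyl in place of 2,4-dichlorophenyl on a double-bonded chain carbon bound to a double-bonded ring carbon, with 3,5-dichlorophenyl in place of 2,4-dichlorophenyl. Among the compounds with values here, no measured compound carries 3,5-dichlorophenyl, so the guidance is indirect. Within the data shown here, the closest precedent is the swap of 2-bromophenyl for 4-bromophenyl, a 1.7-fold lower number from compound 1 to compound 2 (0.22 log units; within the scatter). That step points to a small effect from rearranging the halogens, while the steps to compound 3 leave open a number near or past the limit. A move toward a lower number is expected, with the estimated step being an at least 1.6-fold lower number from compound 3 to compound 4 (0.22 log units; that floor lies within the scatter). For compound 4, the estimated value is 30000 nM, with an expected range from 12000 nM to 70000 nM.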

Compound 4, half-maximal inhibitory concentration: 8300 nM
Compound 4: middle estimate off by 3.6-fold (0.56 log units), on the high side, outside the stated range (below it).
By their numbers in this assay, from the lowest: compounds 4, 2 and 1 (each within the scatter of the next, the first and the last beyond it). At a limit, above all of these: compound 3.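

In this assay, rearranging the two chlorines on the phenyl group, with the atoms themselves unchanged, gives an at least 6.0-fold lower number from compound 3 to compound 4 (0.77 log units; beyond the scatter), so at this position the arrangement of the halogens can matter more than the swap between the two bromophenyl groups suggested. That size is only a floor, since compound 3 stands at a limit of the assay and not at a number: the limit of > 50000 nM in this assay, at which 1 of the 4 values shown sits. The other two new steps are a 1.6-fold lower number from compound 2 to compound 4 (0.20 log units; within the scatter) and a 2.6-fold lower number from compound 1 to compound 4 (0.42 log units; beyond the scatter), the first within the scatter and the second beyond it, so carrying two chlorines does not by itself put a compound at the limit.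

Still open, from the compounds shown here alone, is which of the two chlorines in 2,4-dichlorophenyl goes with the limit, and whether a phenyl group with a single chlorine would read more like compound 3 or compound 4. Also open, going by these compounds, is how this assay would respond at this position to a different kind of group altogether, such as a phenyl group carrying an amine or a carboxylic acid.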